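The source may report more compounds than this note shows. Statements on the series, on what has been measured and on what is new or still open speak of the compounds shown alone.

Series notes. Compound 1 `COc1cc([C@H]2C[C@@]2(CO)C(=O)Nc2ccccc2)cc(OC)c1OC` carries a hydroxymethyl on a saturated ring carbon and a phenyl amide. In a functional assay on HeLa cells (Homo sapiens) for cytotoxicity, read by MTT assay, with a stated time of 48 h (on this read-out lower numbers stand for stronger inhibition and higher numbers for weaker inhibition), compound 1 returns only the assay limit, > 100000 nM. Compound 2 `COc1cc([C@H]2C[C@@]2(CO)C(=O)NCc2ccc(C)cc2)cc(OC)c1OC` likewise returns only the limit in this assay, > 100000 nM. The step that the two limits leave unreadable from compound 1 to compound 2 is therefore unreadable, since both ends sit at the limit of > 100000 nM in this assay, at which 2 of the 3 values shown sit. Compound 3 `CCOC(=O)[C@]1(C(=O)Nc2ccccc2Cl)C[C@H]1c1cc(OC)c(OC)c(OC)c1`, bearing an ethoxycarbonyl and a chlorophenyl amide, gives a read number in this assay, 42400 nM. Compound 4 `CCOC(=O)[C@@]1(C(=O)NCc2ccc(C)cc2)C[C@@H]1c1cc(OC)c(OC)c(OC)c1` differs from compound 2 by ethoxycarbonyl in place of hydroxymethyl on a saturated ring carbon. For the measured compounds named here, no measured step covers this change on its own; compound 2 stands at a limit, and the single read number in the set, that of compound 3, also holds an ethoxycarbonyl. For compound 4 a step of an at least 1.4-fold lower number from compound 2 to compound 4 (0.15 log units; that floor lies within the scatter) is expected, though a further limit remains likely. Compound 4 is estimated at 70000 nM, range 25000 nM to 200000 nM.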

Compound 4, half-maximal inhibitory concentration: > 100000 nM
Compound 4: no number, only a limit; the forecaster's own chance of this, stated with the estimate: 50%; at least 1.4-fold (0.15 log units) between middle value and limit.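

Compound 2 and compound 4 both stand only at the assay limit, so no step can be read for ethoxycarbonyl in place of hydroxymethyl on a saturated ring carbon. The compounds shown leave open whether this exchange alters the read-out at all.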